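A few compounds are considered here, and "the series" means these few. Any claim that something is new, unique, unknown or untested is made for them only; others in the source may bear on it.

Measured so far:
compound 1 `CCCn1c(Cn2c(=O)oc3ccc(C)cc32)n[nH]c1=S`: 160%
compound 2 `CCn1c(Cn2c(=O)oc3ccc(C)cc32)n[nH]c1=S`: 147%
compound 3 `CCNC(=S)NNC(=O)Cn1c(=O)oc2ccc(C)cc21`: 128%

All three were run in a functional assay on the whole organism with Mus musculus as the target, read by paw edema, with a stated time of 360 min, at a dose of 50 mg/kg by the oral route; a higher number here means a weaker effect of the compound at the dose given, a lower number a stronger effect. Compound 1 gives 160%, compound 2 gives 147%, and compound 3 gives 128%. The change from compound 1 to compound 2 is hydrogen in place of methyl on a saturated chain carbon, two bonds along the chain from an aromatic nitrogen, and it made a step of a number 13 percentage points lower from compound 1 to compound 2 (beyond the scatter). Compound 3 and compound 1 have different cores; the difference between the two cores is not broken down here. Compound 3 stands lowest of the three numbers, with both others beyond the scatter above it.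

Compound 4 `CNC(=S)NNC(=O)Cn1c(=O)oc2ccc(C)cc21` is not yet measured in this assay. It differs from compound 3 by hydrogen in place of methyl on a saturated chain carbon bound to an amide-type nitrogen. This is the same kind of change as from compound 1 to compound 2, but the place is not the same: there the carbon was two bonds along the chain from an aromatic nitrogen, here it is bound to an amide-type nitrogen. Among the compounds with values here, the step from compound 3 to compound 4 is expected to be a number 10 percentage points lower from compound 3 to compound 4 (within the scatter), resting on the single earlier step of a number 13 percentage points lower from compound 1 to compound 2 (beyond the scatter), taken with less weight because the place differs and only one example exists. Compound 4 is expected to give about 118%, in a range from 100% to 136%.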

Compound 4, a percentage reported as activity, at one dose (the size of the read-out at that dose, not a potency): 189%
Beside the measured number, compound 4's estimate is 71 percentage points below it; the whole stated range lies below it.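

In this assay the change of ethyl to methyl on a saturated chain carbon bound to an amide-type nitrogen gives a number 61 percentage points higher from compound 3 to compound 4 (beyond the scatter). Set beside the earlier hydrogen-for-methyl step on the core of compound 1, the change does not carry over between the two cores in this series, neither in direction nor in size: the same change on two cores in this assay, a number 13 percentage points lower (beyond the scatter) from compound 1 to compound 2 and a number 61 percentage points higher (beyond the scatter) from compound 3 to compound 4, 74 percentage points apart, beyond the scatter of two such steps

Within the data shown here, this shows that the step on one core gives no usable reading for the other, but it does not show what separates them: the place of the change differs along with the core, each core offers only a single pair, and core and place cannot be told apart.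

Open, as far as these compounds go, is how a methyl chain on the core of compound 1 and a propyl chain on the core of compound 3 would read, since these would give each core a second step of the same kind. Also open, from the compounds shown here alone, is how a longer chain such as butyl, or a phenyl ring, would read on either core.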